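This account rests on a few compounds, and the source may have more. Where it says the series, first, only, none or still open, it means among the compounds named here.

Working notes on the series.

Compound 1 `Clc1ccc(Oc2cncc(C3=CC4CNCC(C3)C4)c2)cc1` gives 40 nM in an in vitro assay on SH-SY5Y cells for displacement of a labelled ligand from Neuronal acetylcholine receptor; alpha3/beta4 (Homo sapiens); on this read-out higher numbers stand for weaker inhibition and lower numbers for stronger inhibition. Going by the values given here, compound 2 `COc1cccc(Oc2cncc(C3=CC4CNCC(C3)C4)c2)c1` gives 15 nM in this assay; on the two numbers available it stands lowest, with compound 1 the nearest point, a 2.7-fold lower number from compound 1 to compound 2 (0.43 log units; beyond the scatter), the one change being 3-methoxyphenyl in place of 4-chlorophenyl on the oxygen on the aromatic ring.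

Compound 3 `COc1cncc(C2=CC3CNCC(C2)C3)c1` is not yet measured. It differs from compound 2 in one place: methyl in place of 3-methoxyphenyl on an oxygen on an aromatic ring. Among the compounds with values here, the only measured step, from compound 1 to compound 2, swaps one aryl group on that oxygen for another and shifts the number modestly; it shows the group on the oxygen matters for the read-out, but no measured step removes the aryl ring altogether, so the size of the present change is not covered by data.

Cutting the substituent on the oxygen down to methyl is expected to raise the number in this assay, and the estimated step is a 6.7-fold higher number from compound 2 to compound 3 (0.82 log units; beyond the scatter). Compound 3 is therefore expected at about 100 nM, within a range of 25 nM to 400 nM.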

Compound 3, inhibition constant: 14.3 nM
For compound 3 the middle estimate is 7.0-fold (0.84 log units) above the measured one; measured number outside the range, below it.
By their numbers in this assay, from the lowest: compounds 3 and 2 (each within the scatter of the next); then compound 1.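

In this assay, the aryl ring on the oxygen on the aromatic ring proves dispensable for this read-out: methyl in place of 3-methoxyphenyl gives a 1.0-fold lower number from compound 2 to compound 3 (0.02 log units; within the scatter), so removing the whole six-membered aromatic ring leaves the number within the scatter. Methyl in place of 4-chlorophenyl gives a 2.8-fold lower number from compound 1 to compound 3 (0.45 log units; beyond the scatter), a modest step, so among the three groups shown on this oxygen, 4-chlorophenyl alone stands apart, while 3-methoxyphenyl and methyl cannot be told apart, however much they differ in size. Nothing available accounts for this insensitivity to the group on the oxygen.

The compounds shown leave open whether the oxygen itself matters, as all three carry it, and whether the flat response extends to other groups there, such as a longer chain, a primary amine or a carboxylic acid. They also leave open whether other aryl groups on this oxygen stay with 3-methoxyphenyl and methyl or with 4-chlorophenyl, and how any of these compounds behave on other receptor subtypes.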